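A few compounds are considered here, and "the series" means these few. Any claim that something is new, unique, unknown or untested is made for them only; others in the source may bear on it.

In a physicochemical assay for lipophilicity, read by HPLC, measured as chromatographic lipophilicity, at pH 7.4 (a lower number here means a more polar compound, a higher number a more lipophilic compound), compound 1 `O=C(C1CCN(c2ccccc2)CC1)N1N=CC[C@H]1c1ccccc1` gives 6.3, compound 3 `CN1CCN(C(=O)C(C)(C)C)C(c2ccccc2)C1` gives 4.9, and compound 2 `O=C(C1CCN(c2ccncn2)CC1)N1N=CC[C@H]1c1ccccc1` gives 3.2, the lowest of the three numbers. Still unmeasured is compound 4 `O=C(C1CCN(c2cccnn2)CC1)N1N=CC[C@H]1c1ccccc1`, which differs from compound 2 in one place: pyridazin-3-yl in place of pyrimidin-4-yl on an amine nitrogen in a ring. Within the data shown here, the only measured step at this place is large, a number 3.10 log units lower from compound 1 to compound 2 (beyond the scatter), but there phenyl left. Among the measured compounds shown here, no measured step swaps one aromatic ring with 2 hetero atoms for another, so only a small downward move in this assay is expected, probably not beyond the scatter. The expected step is a number 0.20 log units lower from compound 2 to compound 4 (within the scatter). For compound 4 the estimated number is 3, within an expected range of 2.5 to 3.5.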

Compound 4, distribution coefficient: 3.4
The estimate for compound 4 lay 0.40 log units below the measured number; the measured number falls inside the stated range.
By their numbers in this assay, from the lowest: compounds 2 and 4 (each within the scatter of the next); then compound 3; then compound 1.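

In this assay, pyridazin-3-yl in place of pyrimidin-4-yl on the amine nitrogen in the ring gives a number 0.20 log units higher from compound 2 to compound 4 (within the scatter), so these two aromatic rings with 2 hetero atoms cannot be told apart at this place. With phenyl as the starting point, pyridazin-3-yl gives a number 2.90 log units lower from compound 1 to compound 4 (beyond the scatter), so the large step is not confined to pyrimidin-4-yl. Nothing measured here accounts for the size of either step. The compounds shown leave open whether a pyridinyl group at this place would fall with compound 1 or with compound 2 and compound 4.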